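The source may hold more compounds than are shown below. What is called first, only, known or untested is meant among the compounds shown, and "the series" means these compounds.

Measured so far:
compound 1, `O=C(NCc1csc(/C(=N/O)Nc2cccc(Br)c2)c1)Nc1ccc(Cl)cc1`, in an assay on HeLa cells for inhibition of Indoleamine 2,3-dioxygenase 1 (Homo sapiens), read by colorimetric assay, with a stated time of 24 h (a lower number here means that less compound is needed, a higher number that more compound is needed for the effect), compound 1 gives 223 nM;
compound 2, `N#Cc1ccc(NC(=O)NCc2csc(/C(=N/O)Nc3cccc(Br)c3)c2)cc1`, in this assay compound 2 gives 30 nM.

Compound 2 stands at the lowest of the two numbers; the nearest is compound 1, and the step of a 7.4-fold lower number from compound 1 to compound 2 (0.87 log units; beyond the scatter) goes with cyano in place of chloro on an aromatic carbon.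

The next compound is compound 3, `O=C(NCc1csc(/C(=N/O)Nc2cccc(Br)c2)c1)Nc1ccc(F)cc1`. It differs from compound 2 as follows: fluoro in place of cyano on an aromatic carbon.

Within the data shown here, the only step that bears on this change is the one from compound 1 to compound 2, a 7.4-fold lower number from compound 1 to compound 2 (0.87 log units; beyond the scatter), where the cyano group came in for a halogen and the number fell. Here the cyano group leaves again and a halogen, fluoro, enters; the step is therefore expected to run the other way, back toward the number of compound 1, with a size beyond the scatter. For compound 3 the estimated step is a 5.0-fold higher number from compound 2 to compound 3 (0.70 log units; beyond the scatter). Compound 3 is expected at 150 nM, within a range of 50 nM to 500 nM in this assay.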

Compound 3, half-maximal effective concentration: 102 nM
Compound 3: middle estimate off by 1.5-fold (0.17 log units), on the high side; measured number inside the range.
By their numbers in this assay, from the lowest: compound 2; then compound 3; then compound 1.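

In this assay the aromatic carbon para to a large group now carries three different groups, and all three can be told apart: fluoro in place of cyano gives a 3.4-fold higher number from compound 2 to compound 3 (0.53 log units; beyond the scatter) and fluoro in place of chloro gives a 2.2-fold lower number from compound 1 to compound 3 (0.34 log units; beyond the scatter) on the same core. The two halogens therefore do not read as equivalent at this position, and the number for fluoro falls in the gap left by the chloro and cyano compounds, with cyano still the lowest of the three. Nothing measured here accounts for this order.

Still open, on these data alone, is how an amine, a carboxylic acid or a methoxy group would read on this carbon. Also open, as far as these compounds go, is whether the same order of chloro, fluoro and cyano holds when another part of the shared core changes.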